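2,3-Dimethylphenyl replaces 4-(trifluoromethyl)phenyl on a ring nitrogen

The compounds below may be only part of what the source reports. "The series", "measured", "known", "first", "only" and "open" are said of these compounds alone.

Compound 1 `Cc1ccc(N2CCN(C(=O)c3oc(C)nc3-c3ccccc3)CC2)cc1` gives > 1000 nM in a functional assay on HL-60 cells (Homo sapiens) for inhibition, read by MTT assay, with a stated time of 72 h (a higher number here means a weaker inhibitor, a lower number a stronger inhibitor), which is a limit of the assay rather than a number.
Compound 2 `Cc1nc(-c2ccccc2)c(C(=O)N2CCN(c3ccccc3Cl)CC2)o1` gives 124 nM in this assay.
Compound 3 `Cc1nc(-c2ccccc2)c(C(=O)N2CCN(c3ccc(C(F)(F)F)cc3)CC2)o1` gives > 1000 nM in this assay, again a limit and not a number.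

Compound 3 therefore sits at the limit of > 1000 nM in this assay, at which 2 of the 3 values shown sit, so its true value is known only as lying past that boundary. The next compound, compound 4 `Cc1nc(-c2ccccc2)c(C(=O)N2CCN(c3cccc(C)c3C)CC2)o1`, keeps the shared core and changes only the group on the ring nitrogen: 2,3-dimethylphenyl in place of 4-(trifluoromethyl)phenyl on an amine nitrogen in a ring.

Two measured steps alter the same group. The step of an at least 8.0-fold lower number from compound 1 to compound 2 (0.90 log units; beyond the scatter) showed that moving from 4-methylphenyl to 2-chlorophenyl brought a clear gain, while the step of an at least 8.0-fold higher number from compound 2 to compound 3 (0.90 log units; beyond the scatter) showed the reverse for 4-(trifluoromethyl)phenyl. The step that the two limits leave unreadable from compound 1 to compound 3 cannot be read because both ends are limits. Compound 4 carries methyl groups like compound 1, yet arranged as 2,3-dimethylphenyl, a pattern not yet tested, so the outcome is open in either direction. Compound 4 is expected to land somewhere between the two measured outcomes, at an estimated 600 nM (range 150 nM to 3000 nM). This estimate corresponds to an expected step of an at least 1.6-fold lower number from compound 3 to compound 4 (0.22 log units; that floor lies within the scatter).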

Compound 4, half-maximal inhibitory concentration: 35 nM
Estimate against measurement, compound 4: 17-fold (1.23 log units) above, outside the stated range (below it).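

Methyl groups on the phenyl ring are not poor in themselves, since their arrangement decides the outcome: going from 4-methylphenyl to 2,3-dimethylphenyl gives an at least 28-fold lower number from compound 1 to compound 4 (1.45 log units; beyond the scatter), and replacing 4-(trifluoromethyl)phenyl with 2,3-dimethylphenyl gives an at least 28-fold lower number from compound 3 to compound 4 (1.45 log units; beyond the scatter). Chlorine is also not needed for good activity, as the all-carbon 2,3-dimethylphenyl improves on 2-chlorophenyl with a 3.5-fold lower number from compound 2 to compound 4 (0.55 log units; beyond the scatter), which makes compound 4 the strongest inhibitor of the four and shows that this position can still separate two active compounds. Among these four compounds, the two with a group numbered 2 on the phenyl ring have measured values, whereas compound 1 and compound 3, with a group numbered 4, give only a limit of the assay and not a number, so the steps from them are minimum sizes: the limit of > 1000 nM in this assay, at which 2 of the 4 values shown sit.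

Going by these compounds, it remains open whether the gain needs both methyl groups, which 2-methylphenyl and 3-methylphenyl would separate. On these data alone, how a methoxy group on the phenyl ring, or a pyridine ring in place of it, would compare with 2,3-dimethylphenyl also remains open.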